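The source may report more compounds than this note shows. Statements on the series, on what has been measured and on what is new or still open speak of the compounds shown alone.

The measured compounds in an ADME assay on CEM-SS cells (Homo sapiens) for cytotoxicity, read by XTT assay, with a stated time of 6 days; on this read-out lower numbers stand for higher toxicity in this test and higher numbers for lower toxicity in this test:
Compound 1 `CCCC(=O)OCSc1ccccc1C(=O)NCCC(N)=O` gives > 100 uM, which is a limit of the assay and not a number.
Compound 2 `CCCC(=O)OCSc1ccccc1C(=O)NC1(C(N)=O)CCCC1` gives > 100 uM, likewise a limit rather than a number.
Compound 3 `CCCC(=O)OCSc1ccccc1C(=O)OCC(N)=O` gives 82.1 uM.

Compound 2 thus stands at the assay's limit, with only a limit and no number in this assay, and compound 1 sits at the same place, (the limit of > 100 uM in this assay, at which 2 of the 3 values shown sit). Compound 4 `CCCC(=O)OCSc1ccccc1C(=O)NCC(=O)NC(C)C` differs from compound 2 by (isopropylcarbamoyl)methyl in place of 1-carbamoylcyclopentyl on an amide-type nitrogen. For the measured compounds named here, of the measured steps, the one that also changes a group on an amide-type nitrogen is a step that the two limits leave unreadable from compound 1 to compound 2, so it gives no size to build on. The other, an at least 1.2-fold lower number from compound 1 to compound 3 (0.08 log units; that floor lies within the scatter), is a change on a carbonyl carbon and is small at its floor. Going by the values given here, no measured step therefore points to a change beyond the scatter, and the expected step of a number no higher from compound 2 to compound 4 (the limit leaves the size open) is accordingly none beyond the scatter. Compound 4 is expected to give about 100 uM in this assay, estimated between 50 uM and 200 uM, most likely reported again only as a limit.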

Compound 4, half-maximal toxic concentration: 92 uM
For compound 4 the middle estimate is 1.1-fold (0.04 log units) above the measured one; the range from low to high includes it.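

In this assay compound 4 gives a number rather than a limit, so (isopropylcarbamoyl)methyl, a group with no ring, gives a readable value at this place on the amide-type nitrogen. Against the earlier compounds held at the limit, the result shows only an at least 1.0-fold lower number from compound 2 to compound 4 (0.03 log units; that floor lies within the scatter) and an at least 1.0-fold lower number from compound 1 to compound 4 (0.03 log units; that floor lies within the scatter) and leaves the true size of both steps open: the limit of > 100 uM in this assay, at which 2 of the 4 values shown sit. For the compounds shown here, compound 3 offers the one full comparison, a 1.1-fold higher number from compound 3 to compound 4 (0.05 log units; within the scatter), so ((isopropylcarbamoyl)methyl)amino and carbamoylmethoxy on the carbonyl carbon read alike in this test.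

On these data alone, whether an amine or a carboxylic acid on the end of this side chain would shift the number beyond the scatter remains open. So does the effect of a longer chain in place of the isopropyl group.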